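Benzyl Substituent Swap on a Quinolone Core

The source may hold more compounds than are shown below. What is called first, only, known or untested is meant among the compounds shown, and "the series" means these compounds.

Measured so far:
In a functional assay on P388 cells (Mus musculus) for cytotoxicity (a higher number here means a weaker inhibitor, a lower number a stronger inhibitor), compound 1 `Cc1cc(-c2c(F)cc3c(=O)c(Cc4ccccc4N)cn(C4CC4)c3c2F)cc(C)n1` gives 2100 nM.
In this assay compound 2 `Cc1cc(-c2c(F)cc3c(=O)c(Cc4c(O)cc(O)cc4O)cn(C4CC4)c3c2F)cc(C)n1` gives 470 nM.

Among the measured compounds shown here, compound 2 holds the lower of the two numbers, with compound 1 the only comparison. For the measured compounds named here, the step of a 4.5-fold lower number from compound 1 to compound 2 (0.65 log units; beyond the scatter) is the one change at this position. Compound 3 `COc1cccc(Cc2cn(C3CC3)c3c(F)c(-c4cc(C)nc(C)c4)c(F)cc3c2=O)c1` carries a further change there: 3-methoxyphenyl in place of 2,4,6-trihydroxyphenyl on a saturated chain carbon bound to an aromatic carbon. Since compound 1, which also lacks the three hydroxyls, sits higher, a rise is expected: a 3.2-fold higher number from compound 2 to compound 3 (0.50 log units; beyond the scatter). Compound 3 is estimated at 1500 nM, within 400 nM to 5000 nM.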

Compound 3, half-maximal inhibitory concentration: 20000 nM
Estimate against measurement, compound 3: 13-fold (1.12 log units) below; measured number above the stated range.
By their numbers in this assay, from the lowest: compound 2; then compound 1; then compound 3.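

In this assay, 3-methoxyphenyl in place of 2,4,6-trihydroxyphenyl on a saturated chain carbon brings a 43-fold higher number from compound 2 to compound 3 (1.63 log units; beyond the scatter) as the largest step seen at this place. It also stands apart from 2-aminophenyl, with a 9.5-fold higher number from compound 1 to compound 3 (0.98 log units; beyond the scatter), so the groups without the three hydroxyls do not share one level. Nothing available gives a reason for either step.

Which part of the change carries the rise stays open. A 3-hydroxyphenyl or a 2,4,6-trimethoxyphenyl on the same carbon would separate the methoxy group from the loss of the hydroxyl groups.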